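The source may report more compounds than this note shows. Statements on the series, on what has been measured and on what is new or still open speak of the compounds shown alone.

In a functional assay on A549 cells (Homo sapiens) for inhibition, read by MTT assay, with a stated time of 72 h (a higher number here means a weaker inhibitor, a lower number a stronger inhibitor), the measured compounds are
compound 1 `O=C(Nc1ccccc1)C1CCN(C/C=C/c2ccccc2)CC1` with 69700 nM
compound 2 `Cc1ccc(NC(=O)C2CCN(C/C=C/c3ccccc3)CC2)cc1` with 29600 nM
compound 3 `COc1ccc(NC(=O)C2CCN(C/C=C/c3ccccc3)CC2)cc1` with 83800 nM

Compound 2 has the lowest number of the three, and its steps to both others lie beyond the scatter. Compound 4 (`COc1cccc(NC(=O)C2CCN(C/C=C/c3ccccc3)CC2)c1`) has not been measured. It carries 3-methoxyphenyl in place of 4-methylphenyl on an amide-type nitrogen. The closest evidence is methoxy in place of methyl on an aromatic carbon (a 2.8-fold higher number from compound 2 to compound 3 (0.45 log units; beyond the scatter)). Methyl in place of hydrogen (a 2.4-fold lower number from compound 1 to compound 2 (0.37 log units; beyond the scatter)) and methoxy in place of hydrogen (a 1.2-fold higher number from compound 1 to compound 3 (0.08 log units; within the scatter)) also bear on it. For the measured compounds named here, no measured compound carries the 3-methoxyphenyl group, so a modest rise in this assay is expected, not a firm one. The expected change is (a 2.0-fold higher number from compound 2 to compound 4 (0.31 log units; beyond the scatter)) in size. For compound 4 the estimated value is 60000 nM, with an expected range from 25000 nM to 140000 nM.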

Compound 4, half-maximal inhibitory concentration: 50500 nM
Beside the measured number, compound 4's estimate is 1.2-fold (0.07 log units) above it, within the range that was stated.
By their numbers in this assay, from the lowest: compounds 2, 4, 1 and 3 (each within the scatter of the next, the first and the last beyond it).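

In this assay 3-methoxyphenyl on the amide-type nitrogen cannot be told apart from 4-methylphenyl (a 1.7-fold higher number from compound 2 to compound 4 (0.23 log units; within the scatter)) or from 4-methoxyphenyl (a 1.7-fold lower number from compound 3 to compound 4 (0.22 log units; within the scatter)), and methoxy in place of hydrogen on an aromatic carbon also gives a step that stays small (a 1.4-fold lower number from compound 1 to compound 4 (0.14 log units; within the scatter)). Compound 4 thus lies within the scatter of each of the other three compounds, although compound 2 and compound 3 lie beyond it from each other. Nothing available explains these numbers. As far as these compounds go, whether 3-methylphenyl, a chloro group or an amine on this aromatic ring would give a step beyond the scatter stays open.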